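Swapping a Nitrile for a Methylsulfonyl Group

The source may report more compounds than this note shows. Statements on the series, on what has been measured and on what is new or still open speak of the compounds shown alone.

Going by the values given here, compound 2 `N#Cc1ccc(-c2csc(N3N=C(c4ccc(N5CCCCC5)cc4)CC3c3ccc(Cl)cc3)n2)cc1` is the only compound here with a numeric result: in a functional assay on MCF7 cells (Homo sapiens) for antiproliferative activity, read by MTT assay, with a stated time of 72 h (on this read-out higher numbers stand for weaker inhibition and lower numbers for stronger inhibition), compound 2 gives 9760 nM. Compound 1 `Clc1ccc(C2CC(c3ccc(N4CCCCC4)cc3)=NN2c2nc(-c3ccc(Br)cc3)cs2)cc1` differs from it only by a bromo group in place of the cyano group; in this assay compound 1 reached only a limit of the assay, > 100000 nM. Among the compounds with values here, the step of an at least 10-fold lower number from compound 1 to compound 2 (1.01 log units; beyond the scatter) is the single measured step, and it was large, though it is a step from a limit of > 100000 nM in this assay, at which 1 of the 2 values shown sits, rather than between two numbers.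

Compound 3 `CS(=O)(=O)c1ccc(-c2csc(N3N=C(c4ccc(N5CCCCC5)cc4)CC3c3ccc(Cl)cc3)n2)cc1` carries the change (methylsulfonyl in place of cyano on an aromatic carbon), on an aromatic carbon of a six-membered aromatic ring of carbon only. Within the data shown here, no measured step touches a methylsulfonyl group, so the bromo-to-cyano step gives no direct guide to its size or direction. Without any such evidence, the expectation for compound 3 is a step of a 1.0-fold higher number from compound 2 to compound 3 (0.01 log units; within the scatter) that stays within the scatter. The estimate for compound 3 in this assay is therefore 10000 nM, with a range from 3000 nM to 40000 nM.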

Compound 3, half-maximal inhibitory concentration: > 100000 nM
Compound 3: only a limit was reported (the forecaster's own chance of this, stated with the estimate: 15%); at least 10-fold (1.00 log units) between middle value and limit.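

Putting a methylsulfonyl group in place of the cyano group at this same place, para to a large group, gives an at least 10-fold higher number from compound 2 to compound 3 (1.01 log units; beyond the scatter) in this assay, and this step too ends at a limit of the assay rather than at a number. Bromo-to-cyano had shown that a change here can bring a measurable result, and this swap shows that the result can be lost again with a different group on the same aromatic carbon, so of the three groups shown, only the cyano group of compound 2 gives a number. The comparison of compound 1 with compound 3 cannot be read, because both stand at the same limit: the limit of > 100000 nM in this assay, at which 2 of the 3 values shown sit.

Going by these compounds, how much activity compound 1 and compound 3 might really have, and so whether the bromo and methylsulfonyl groups differ at all, stays open. Also open, on these data alone, is what other groups on this carbon, such as an amine, a carboxylic acid or a methoxy group, would do, and whether any of them would give a lower number than the cyano group.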